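This account rests on a few compounds, and the source may have more. Where it says the series, first, only, none or still open, it means among the compounds named here.

The measured compounds:
Compound 1, `COc1ccc2c(=O)c(/C=C/C(=O)Nc3cccc(Cl)c3)coc2c1`. In a functional assay (QGY7701 cells, Homo sapiens) for inhibition, read by MTT assay, with a stated time of 48 h (a lower number here means a stronger inhibitor, a higher number a weaker inhibitor), compound 1 gives > 100000 nM, which is a limit of the assay and not a number.
Compound 2, `COc1ccc(CNC(=O)/C=C/c2coc3cc(OC)ccc3c2=O)cc1`. In this assay compound 2 gives 15700 nM.
Compound 3, `COc1ccc(NC(=O)/C=C/c2coc3cc(OC)ccc3c2=O)cc1`. In this assay compound 3 gives > 100000 nM, again a limit of the assay rather than a number.

Compound 3 therefore stands at the top of what the assay can report, and it shares that position with compound 1: the limit of > 100000 nM in this assay, at which 2 of the 3 values shown sit. Only compound 2 gives an actual number.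

Compound 4, `COc1ccc2c(=O)c(/C=C/C(=O)NCc3ccc(F)cc3F)coc2c1`, differs from compound 3 in one place: 2,4-difluorobenzyl in place of 4-methoxyphenyl on an amide-type nitrogen. Within the data shown here, two measured steps bear on this exchange, and both point the same way. One is an at least 6.3-fold lower number from compound 1 to compound 2 (0.80 log units; beyond the scatter); the other is an at least 6.3-fold higher number from compound 2 to compound 3 (0.80 log units; beyond the scatter). In both, the 4-methoxybenzyl compound gave the lower number and the phenyl-type amides sat at the limit; the pair of compounds 1 and 3 shows nothing readable between the two phenyl-type groups, since both are limits.

Compound 4 again carries a benzyl-type group, 2,4-difluorobenzyl, so a number below the limit is expected, roughly where compound 2 lies. The expected step for compound 4 is an at least 5.0-fold lower number from compound 3 to compound 4 (0.69 log units; beyond the scatter). For compound 4 the estimate is 20000 nM, within 5000 nM to 80000 nM.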

Compound 4, half-maximal inhibitory concentration: > 100000 nM
Compound 4 ended at the assay's limit; the forecaster's own chance of this, stated with the estimate: 25%; middle value at least 5.0-fold (0.69 log units) from the limit.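

Among the earlier compounds, only compound 2 carried a benzyl-type group on the amide-type nitrogen, and only compound 2 gave an actual number, so that group alone might have seemed enough. Compound 4 goes against this pattern. In this assay there is an at least 6.3-fold higher number from compound 2 to compound 4 (0.80 log units; beyond the scatter), so a saturated chain carbon on that nitrogen does not by itself give a readable value, and the ring attached to that carbon also matters. The steps from compound 1 and from compound 3 to compound 4 cannot be read, as each joins two limits, and compound 2 stays the only compound with an actual number: the limit of > 100000 nM in this assay, at which 3 of the 4 values shown sit.

The compounds shown leave open whether the value of compound 2 depends on the methoxy group in particular or whether the two fluorines of compound 4 are what remove a readable value, as neither ring change has been separated into single steps. They also leave open whether an unsubstituted benzyl group, a dimethylamino group on the ring, or a longer chain such as 2-phenylethyl on the amide-type nitrogen would give a number below the limit.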